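This account rests on a few compounds, and the source may have more. Where it says the series, first, only, none or still open, it means among the compounds named here.

Of the compounds shown here, three sharing one core have been tested in a functional assay on HepG2 cells (Homo sapiens) for inhibition, read by sulforhodamine B assay, with a stated time of 72 h; a higher number here means a weaker inhibitor, a lower number a stronger inhibitor. In this test compound 1 `C[C@H](Nc1ncnc2[nH]cnc12)c1nn(-c2cccc(F)c2)c2cc(F)ccc12` gives 32300 nM, compound 2 `C[C@H](Nc1ncnc2[nH]cnc12)c1nn(-c2ccc(C#N)cc2)c2cc(F)ccc12` gives 15100 nM and compound 3 `C[C@H](Nc1ncnc2[nH]cnc12)c1nn(-c2ccccn2)c2cc(F)ccc12` gives 29900 nM. Compound 3 stands within the usual scatter of both others: the data show a 1.1-fold lower number from compound 1 to compound 3 (0.03 log units; within the scatter) and a 2.0-fold higher number from compound 2 to compound 3 (0.30 log units; within the scatter). The next structure is compound 4 `C[C@H](Nc1ncnc2[nH]cnc12)c1nn(-c2cccc(S(C)(=O)=O)c2)c2cc(F)ccc12`, and its difference from compound 3 is 3-(methylsulfonyl)phenyl in place of pyridin-2-yl on an aromatic nitrogen. In words, a 3-(methylsulfonyl)phenyl group replaces pyridin-2-yl on an aromatic nitrogen. All three measured steps are swaps at this same place, so they are the best guide available. The largest of them is a 2.1-fold lower number from compound 1 to compound 2 (0.33 log units; beyond the scatter), which is a modest move. Going by these compounds, none of the tested compounds carries a methylsulfonyl group, so the new group itself remains untested. No step beyond the scatter is therefore expected in this assay, and no direction is favoured. The expected outcome is a 1.2-fold lower number from compound 3 to compound 4 (0.06 log units; within the scatter). For compound 4 the estimated value is 26000 nM, with an expected range of 11000 nM to 60000 nM.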

Compound 4, half-maximal inhibitory concentration: 14800 nM
The estimate for compound 4 lay 1.8-fold (0.24 log units) above the measured number; the range from low to high includes it.
By their numbers in this assay, from the lowest: compounds 4, 2, 3 and 1 (each within the scatter of the next, the first and the last beyond it).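

In this assay, compound 4 shows that this aromatic nitrogen accepts a larger group, 3-(methylsulfonyl)phenyl, without any loss: there is a 2.0-fold lower number from compound 3 to compound 4 (0.31 log units; beyond the scatter), and exchanging fluoro for methylsulfonyl on the phenyl ring gives a 2.2-fold lower number from compound 1 to compound 4 (0.34 log units; beyond the scatter). Both steps are modest, and the comparison with the nitrile-bearing compound shows no separation, with a 1.0-fold lower number from compound 2 to compound 4 (0.01 log units; within the scatter), so 4-cyanophenyl and 3-(methylsulfonyl)phenyl stand at the same level here. Nothing available explains why the numbers differ in this way.

Going by these compounds, it remains open whether a phenyl group carrying an amine or a carboxylic acid would move the number further than these modest steps. On these data alone, it is also open whether any swap at this nitrogen can reach much lower numbers, since all four compounds lie close together.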